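Hydroxy on the phenoxy ring: forecast for compound 4

The compounds below may be only part of what the source reports. "The series", "measured", "known", "first", "only" and "open" are said of these compounds alone.

Three compounds of the series have numbers in an assay on SH-SY5Y cells for inhibition of Voltage-dependent N-type calcium channel subunit alpha-1B (Homo sapiens), read by FLIPR and calcium flux, with stated times of 600 s and 300 s, in the presence of a further agent that is not named here; a higher number here means a weaker inhibitor, a lower number a stronger inhibitor. Compound 1 `CN(Cc1ccc(OCCCN)cc1)c1nc2ccc(Oc3ccccc3)cc2s1` gives 49000 nM; compound 2 `CN(Cc1ccc(OCCCNC(=N)N)cc1)c1nc2ccc(Oc3ccccc3)cc2s1` gives 113000 nM; compound 3 `NCCCOc1ccc(CNc2nc3ccc(Oc4ccccc4)cc3s2)cc1` gives 218000 nM. Compound 1 thus has the lowest number of the three: the step of a 2.3-fold higher number from compound 1 to compound 2 (0.36 log units; beyond the scatter) and the step of a 4.4-fold higher number from compound 1 to compound 3 (0.65 log units; beyond the scatter) both run uphill from it, each beyond the scatter but only modestly. Compound 4 `CN(Cc1ccc(OCCCN)cc1)c1nc2ccc(Oc3ccc(O)cc3)cc2s1` has not yet been measured in this assay. It differs from compound 1 only by hydroxy in place of hydrogen on an aromatic carbon. Among the measured compounds shown here, neither measured step bears on this change: the one to compound 2 adds a group on an amine nitrogen, the one to compound 3 removes a methyl from a nitrogen on an aromatic ring, and neither touches the phenoxy ring. For the measured compounds named here, there is no precedent in this assay for a hydroxy at that position, so the two known steps serve only as a rough sense of how much a single change has moved the number here. Without a direct guide, the expectation for compound 4 is a step of no change at the digits printed from compound 1 to compound 4 (within the scatter), with a range wide enough to admit a modest move either way. Compound 4 is estimated at 49000 nM, between 18000 nM and 130000 nM.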

Compound 4, half-maximal inhibitory concentration: 117000 nM
Estimate against measurement, compound 4: 2.4-fold (0.38 log units) below; the range from low to high includes it.
By their numbers in this assay, from the lowest: compound 1; then compounds 2, 4 and 3 (each within the scatter of the next).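

In this assay the phenoxy ring is not a silent position: hydroxy in place of hydrogen, on an aromatic carbon para to a large group, gives a 2.4-fold higher number from compound 1 to compound 4 (0.38 log units; beyond the scatter), so phenoxy to 4-hydroxyphenoxy is a modest change but one that can be read beyond the scatter. This is the only change shown on that ring, and it places a third site, far from the amine end and the nitrogen on the aromatic ring, among those where a single change from compound 1 raises the number. All three single changes shown from compound 1 run the same way, with no compound among those shown going against this, though three steps at three different sites make a small sample. Nothing measured here accounts for the step at the phenoxy ring.

As far as these compounds go, whether this rise belongs to hydroxy itself or would also follow a methoxy, a fluorine or an amine at the same place remains open. Also open, from the compounds shown here alone, is whether hydroxy would move the number in the same way on the chain end of compound 2 or with the hydrogen on nitrogen of compound 3.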